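The compounds below may be only part of what the source reports. "The series", "measured", "known", "first", "only" and "open" are said of these compounds alone.

Going by the values given here, in a physicochemical assay for solubility, read by mass spectrometry, in phosphate buffer, with a stated time of 24 h, at pH 7.4 (on this read-out higher numbers stand for higher solubility and lower numbers for lower solubility), compound 1 (`CCOC(=O)N1CCC(NC(=O)Nc2ccc(OC(F)(F)F)c(F)c2)CC1`) gives 0.35 ug/mL as the lower of the two numbers measured so far. Among the compounds with values here, the only other measured compound, compound 2 (`O=C(Nc1ccc(OC(F)(F)F)cc1)NC1CCN(C(=O)C2CCOC2)CC1`), gives 29 ug/mL and that gap lies well beyond the usual scatter of repeat measurements. Compound 3 (`CCC(=O)N1CCC(NC(=O)Nc2ccc(OC(F)(F)F)c(F)c2)CC1`) has not yet been measured. It departs from compound 1 in one place (ethyl in place of ethoxy on a carbonyl carbon), with ethyl in place of ethoxy on a carbonyl carbon, so that ethoxycarbonyl becomes propanoyl. Within the data shown here, no pair of measured compounds isolates a single change, so the data give no direct guide to the size of this step. Compound 2 shows that a much higher number is possible, but it differs from compound 1 in more than one place and is only a loose hint. A moderate rise beyond the scatter is therefore expected, and the estimated step is an 8.6-fold higher number from compound 1 to compound 3 (0.93 log units; beyond the scatter) in the upward direction. For compound 3 the estimated value is 3 ug/mL with an expected range from 0.6 ug/mL to 15 ug/mL in this measurement.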

Compound 3, solubility: 11 ug/mL
The estimate for compound 3 lay 3.7-fold (0.56 log units) below the measured number; measured number inside the range.
By their numbers in this assay, from the lowest: compound 1; then compound 3; then compound 2.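

Going by these compounds alone, replacing ethoxy with ethyl on a carbonyl carbon, with the rest of the structure unchanged, gives a 31-fold higher number from compound 1 to compound 3 (1.50 log units; beyond the scatter) in this assay, and this is the first comparison in which only one place differs. It shows that this position, on a carbonyl carbon attached to an amide-type nitrogen in a ring, is not a silent one for this read-out: turning ethoxycarbonyl into propanoyl moves the number far beyond the usual scatter, even though the edit is small and the shared core stays the same. No measurement shown explains why so small an edit produces so large a step.

The compounds shown leave open how a longer chain, a small ring or an amine on this same carbonyl carbon would read in this assay, so it is not yet known whether propanoyl is unusual or typical among such groups. Within the data shown here, with only one pair to go on, it also remains open whether the same swap of ethoxy for ethyl would give a step of similar size on a different core.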